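This account rests on a few compounds, and the source may have more. Where it says the series, first, only, none or still open, it means among the compounds named here.

Two compounds of the series have so far been run in a functional assay on the whole organism for inhibition, with Rattus norvegicus as the target, read by paw edema, with a stated time of 4 h, at a dose of 50 mg/kg; a lower number here means less inhibition, a higher number more inhibition at the dose given (going by the name of the read-out). Compound 1 `CC(=O)c1c(NNc2ccc(Cl)cc2)cc(C)oc1=O` gives 28.4% there. Compound 2 `Cc1ccc(-n2nc3cc(C)oc(=O)c3c2C)cc1` gives 41.7% in this assay, the higher of the two numbers, and its gap from compound 1 lies beyond the scatter. Compound 3 `Cc1cc2nn(-c3ccc(Br)cc3)c(C)c2c(=O)o1` is not yet measured. It differs from compound 2 in one place: bromo in place of methyl on an aromatic carbon. For the measured compounds named here, no measured pair bears on this change, so the step expected in this assay is a number 0.3 percentage points higher from compound 2 to compound 3 (within the scatter), none beyond the scatter in either direction. Compound 3 is therefore estimated at 42% in this assay, within a range of 28% to 56%.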

Compound 3, a percentage reported as inhibition, in the whole organism at one dose (the size of the read-out at that dose, not a potency): 38.2%
Beside the measured number, compound 3's estimate is 3.8 percentage points above it; measured number inside the range.
By their numbers in this assay, from the lowest: compounds 1, 3 and 2 (each within the scatter of the next, the first and the last beyond it).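

On the aromatic carbon para to a large group, bromo in place of methyl gives a number 3.5 percentage points lower from compound 2 to compound 3 (within the scatter) in this assay. This first pair differing in one place shows that, at the dose given, methyl and bromo at this position cannot be told apart, though one pair says nothing about other groups. No measurement at hand explains the step. From the compounds shown here alone, whether an amine or a carboxylic acid on this aromatic carbon would give a step beyond the scatter remains open, as does the result for a longer chain there.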